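A few compounds are considered here, and "the series" means these few. Any claim that something is new, unique, unknown or untested is made for them only; others in the source may bear on it.

Measured compounds:
Compound 1, `CCc1c(Cc2ccccc2Br)nc(SCc2ccc([N+](=O)[O-])cc2)[nH]c1=O`: in an ADME assay on MT4 cells (Homo sapiens) for cytotoxicity, read by MTT assay (a lower number here means that less compound is tolerated, a higher number that more compound is tolerated), compound 1 gives > 272000 nM, which is a limit of the assay and not a number.
Compound 2, `CCc1c(Cc2cccc(Br)c2)nc(SCc2ccc(OC)cc2)[nH]c1=O`: in this assay compound 2 gives 201000 nM.

Compound 2 thus holds the only actual number shown in this assay; the other entry is a limit, described by the limit of > 272000 nM in this assay, at which 1 of the 2 values shown sits. Within the data shown here, no step between two measured compounds that differ in a single place is available, so the size of such a step is not known from these data.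

Compound 3, `CCc1c(Cc2cccc(Br)c2)nc(SCc2ccc([N+](=O)[O-])cc2)[nH]c1=O`, differs from compound 2 by nitro in place of methoxy on an aromatic carbon. The same nitro group is carried by compound 1, which in this assay gives > 272000 nM, a limit. On that basis the step is expected to be small, if anything in the direction of more compound tolerated, and it may not exceed the usual scatter. Compound 3 is therefore estimated at 260000 nM, with a range from 130000 nM to 500000 nM. The expected step of a 1.3-fold higher number from compound 2 to compound 3 (0.11 log units; within the scatter) may well end at the limit of the assay.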

Compound 3, half-maximal cytotoxic concentration: 187000 nM
Estimate against measurement, compound 3: 1.4-fold (0.14 log units) above, and the stated range covers the measured number.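

In this assay, among these compounds, nitro in place of methoxy, on an aromatic carbon para to a large group, gives a 1.1-fold lower number from compound 2 to compound 3 (0.03 log units; within the scatter), so for the first time this single change can be read directly, and with 3-bromophenyl held constant it makes no difference beyond normal repeat variation. Among the compounds shown here, the compounds also now give a first reading of the bromophenyl group, with nitro held constant: 3-bromophenyl in place of 2-bromophenyl gives an at least 1.4-fold lower number from compound 1 to compound 3 (0.16 log units; that floor lies within the scatter), which is only a floor and, as printed, lies within the scatter. The true size of that step stays unknown, since the entry for compound 1 is a limit and not a number: the limit of > 272000 nM in this assay, at which 1 of the 3 values shown sits.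

Two groups at one position cannot show whether this tolerance to change extends further, so an amine or a carboxylic acid on the same aromatic carbon could behave differently. On these data alone, it also remains open whether the methoxy-to-nitro change would look the same with 2-bromophenyl in place of 3-bromophenyl, or whether a longer chain on the shared core would move the number beyond the scatter.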